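Swapping Chloro for Methyl: Expected Paw Edema Inhibition

The source may hold more compounds than are shown below. What is called first, only, known or untested is meant among the compounds shown, and "the series" means these compounds.

Of the compounds shown here, three have been measured in a functional assay on the whole organism (strain Wister albino) for inhibition, with Rattus norvegicus as the target, read by paw edema, with stated times of 1 h and 3 h, at a dose of 50 mg/kg by the intraperitoneal route; on this read-out higher numbers stand for more inhibition at the one dose given (going by the name of the read-out) and lower numbers for less inhibition. Compound 1 `Cc1ccc([C@@H]2CN(C)[C@]3(C(=O)Nc4ccccc43)[C@]23Cc2ccccc2C3=O)cc1` gives 27.4%. Compound 2 `CN1C[C@@H](c2ccc(Cl)cc2)[C@@]2(Cc3ccccc3C2=O)[C@@]12C(=O)Nc1ccccc12` gives 18.9%, and compound 3 `CN1C(=O)[C@@]2(c3ccccc31)N(C)C[C@@H](c1ccc(Cl)cc1)[C@@]21Cc2ccccc2C1=O` gives 9.4%. Between compound 2 and compound 1 the change is methyl in place of chloro on an aromatic carbon, and the measured step is a number 8.5 percentage points higher from compound 2 to compound 1 (within the scatter). Compound 3 differs from compound 2 by methyl in place of hydrogen on an amide-type nitrogen in a ring, a step of a number 9.5 percentage points lower from compound 2 to compound 3 (within the scatter). Compound 4 `Cc1ccc([C@@H]2CN(C)[C@]3(C(=O)N(C)c4ccccc43)[C@]23Cc2ccccc2C3=O)cc1` has not yet been measured; it differs from compound 3 by methyl in place of chloro on an aromatic carbon, the same change as from compound 2 to compound 1, with the two cores differing only as just described. Since the same change earlier gave a number 8.5 percentage points higher from compound 2 to compound 1 (within the scatter), the expected step is a number 8.6 percentage points higher from compound 3 to compound 4 (within the scatter). Compound 4 is therefore expected to give 18%, with an expected range from 6% to 32%.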

Compound 4, a percentage reported as inhibition, in the whole organism at one dose (the size of the read-out at that dose, not a potency): 6.4%
For compound 4 the middle estimate is 11.6 percentage points above the measured one; low and high end bracket the measured number.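

In this assay, methyl in place of chloro on the aromatic carbon gives a number 3 percentage points lower from compound 3 to compound 4 (within the scatter), and this step does not differ from its earlier counterpart by more than the scatter allows: the same change on two cores in this assay, a number 8.5 percentage points higher (within the scatter) from compound 2 to compound 1 and a number 3 percentage points lower (within the scatter) from compound 3 to compound 4, 11.5 percentage points apart, within the scatter of two such steps Methyl in place of hydrogen on the amide-type nitrogen gives a number 21 percentage points lower from compound 1 to compound 4 (beyond the scatter), and this step also agrees with its earlier counterpart: the same change on two cores in this assay, a number 9.5 percentage points lower (within the scatter) from compound 2 to compound 3 and a number 21 percentage points lower (beyond the scatter) from compound 1 to compound 4, 11.5 percentage points apart, within the scatter of two such steps The swap of chloro for methyl thus carried from one core to the other without a difference that stands clear of the scatter, but two small steps of opposite sign show neither a fixed size nor a fixed direction for it.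

The compounds shown leave open what a methoxy group or an amine would do in place of chloro or methyl on the aromatic ring. They also leave open what a longer chain would do in place of methyl on the amide-type nitrogen.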